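The source may hold more compounds than are shown below. What is called first, only, known or untested is meant among the compounds shown, and "the series" means these compounds.

Measured in an ADME assay on microsomes from liver (Homo sapiens) for metabolic stability, with a stated time of 30 min; a higher number here means that more of the compound is left, a lower number that less of the compound is left:
- Compound 1 `CN(C)C(=O)N[C@@H](CO)C(=O)O`: 34%
- Compound 2 `CC(C)C(=O)N[C@@H](CO)C(=O)O`: 84%
- Compound 3 `COC(=O)N[C@@H](CO)C(=O)O`: 43%

Compound 3 sits level with compound 1 within the scatter, well short of compound 2. The change to compound 4 `C=C(C)C(=O)N[C@@H](CO)C(=O)O` is 1-methylethenyl in place of methoxy on a carbonyl carbon.

The closest guide is the all-carbon isopropyl group of compound 2. Swapping it for methoxy gives a number 41 percentage points lower from compound 2 to compound 3 (beyond the scatter). Swapping dimethylamino for isopropyl gives a similar a number 50 percentage points higher from compound 1 to compound 2 (beyond the scatter), whereas swapping dimethylamino for methoxy gives only a number 9 percentage points higher from compound 1 to compound 3 (within the scatter). Among the compounds with values here, no measured compound carries the double bond, so a rise smaller than the full gap is expected. The expected change is a number 27 percentage points higher from compound 3 to compound 4 (beyond the scatter). Compound 4 is estimated at 70%, with an expected range from 48% to 90%.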

Compound 4, percent of the compound remaining: 82%
Beside the measured number, compound 4's estimate is 12 percentage points below it; measured number inside the range.
By their numbers in this assay, from the lowest: compounds 1 and 3 (each within the scatter of the next); then compounds 4 and 2 (each within the scatter of the next).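

With the double bond of 1-methylethenyl in place of isopropyl on the carbonyl carbon, the number holds: a number 2 percentage points lower from compound 2 to compound 4 (within the scatter). Against the groups attached through oxygen or nitrogen, the gain is large, with a number 39 percentage points higher from compound 3 to compound 4 (beyond the scatter) and a number 48 percentage points higher from compound 1 to compound 4 (beyond the scatter), so compound 4 joins compound 2 as a second all-carbon group at the high end. Nothing available explains this difference. Going by these compounds, whether the high numbers depend on branching stays open, and an unbranched propyl chain on the carbonyl carbon would test that.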